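The source may report more compounds than this note shows. Statements on the series, on what has been measured and on what is new or still open speak of the compounds shown alone.

In a functional assay on MDA-MB-231 cells (Homo sapiens) for cytotoxicity, read by MTT assay, with a stated time of 72 h (on this read-out higher numbers stand for weaker inhibition and lower numbers for stronger inhibition), compound 3 `O=C(CN1CCN(c2nnc(Cc3ccncc3)c3ccccc23)CC1)Nc1cccc(F)c1` gives 4.4 nM. Of the three numbers shown it sits together with compound 2 `O=C(CN1CCN(c2nnc(Cc3ccncc3)c3ccccc23)CC1)Nc1ccc(F)c(Cl)c1`, which gives 4 nM; the step of a 1.1-fold higher number from compound 2 to compound 3 (0.04 log units; within the scatter) lies within the scatter. Compound 1 `Cc1cccc(Cl)c1NC(=O)CN1CCN(c2nnc(Cc3ccncc3)c3ccccc23)CC1` gives 2670 nM, and the steps of a 670-fold lower number from compound 1 to compound 2 (2.82 log units; beyond the scatter) and a 610-fold lower number from compound 1 to compound 3 (2.78 log units; beyond the scatter) are both large. Compound 4 `O=C(CN1CCN(c2nnc(Cc3ccncc3)c3ccccc23)CC1)Nc1ccc(Br)cc1` differs from compound 3 by 4-bromophenyl in place of 3-fluorophenyl on an amide-type nitrogen. The measured step that bears on this exchange of one substituted phenyl for another is a 1.1-fold higher number from compound 2 to compound 3 (0.04 log units; within the scatter), which stayed within the scatter; the two large steps both involve the 2-chloro-6-methylphenyl and so do not apply here. No step beyond the scatter is therefore expected in this assay, in either direction. Compound 4 is estimated at 6 nM, with a range of 2 nM to 25 nM, which means an expected step of a 1.4-fold higher number from compound 3 to compound 4 (0.13 log units; within the scatter).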

Compound 4, half-maximal inhibitory concentration: 19 nM
Beside the measured number, compound 4's estimate is 3.2-fold (0.50 log units) below it, and the stated range covers the measured number.
By their numbers in this assay, from the lowest: compounds 2 and 3 (each within the scatter of the next); then compound 4; then compound 1.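

In this assay, the group on the amide-type nitrogen proves less interchangeable than compound 2 and compound 3 alone suggested: 4-bromophenyl gives modest steps beyond the scatter (a 4.3-fold higher number from compound 3 to compound 4 (0.64 log units; beyond the scatter)) and (a 4.8-fold higher number from compound 2 to compound 4 (0.68 log units; beyond the scatter)). The number for compound 4 nevertheless stays far from that of the 2-chloro-6-methylphenyl compound (a 140-fold lower number from compound 1 to compound 4 (2.15 log units; beyond the scatter)). No evidence here bears on the origin of these steps.

3-fluorophenyl and 4-bromophenyl differ in both halogen and substitution position, so the two changes remain unseparated. Also open, from the compounds shown here alone, is how a phenyl carrying an amine or a carboxylic acid would read on this nitrogen.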